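The source may hold more compounds than are shown below. What is called first, only, known or untested is meant among the compounds shown, and "the series" means these compounds.

Compound 1 `Cc1ccccc1S(=O)(=O)n1c(=O)[nH]c2ccc(Cl)cc21`: > 387000 nM
Compound 2 `Cc1ccc(S(=O)(=O)n2c(=O)[nH]c3ccc(Cl)cc32)cc1`: 134000 nM

Going by the values given here, in an ADME assay on MT4 cells (Homo sapiens) for cytotoxicity (on this read-out lower numbers stand for higher toxicity in this test and higher numbers for lower toxicity in this test), compound 2 gives 134000 nM, the only true number so far. The reading for compound 1 is a limit of the assay, not a number.

Compound 3 `Cc1ccc(S(=O)(=O)n2c(=O)[nH]c3ccc(Cl)cc32)c(C)c1` changes compound 2 in one place: methyl in place of hydrogen on an aromatic carbon. A methyl replaces a hydrogen on an aromatic carbon, ortho to a large group and meta to a methyl group.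

Among the compounds with values here, only one measured step bears on this: an at least 2.8-fold lower number from compound 1 to compound 2 (0.46 log units; beyond the scatter). It goes beyond the scatter and is at least modest, but it moves a methyl rather than adding one, so it guides only loosely. Compound 1 has its methyl ortho to a large group and sits on the higher side of that step, so a small rise in this assay is expected, perhaps no larger than the scatter. The expected change is a 1.4-fold higher number from compound 2 to compound 3 (0.15 log units; within the scatter). The estimate for compound 3 is 190000 nM, with an expected range of 90000 nM to 380000 nM.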

Compound 3, half-maximal cytotoxic concentration: 39300 nM
Compound 3: middle estimate off by 4.8-fold (0.68 log units), on the high side; the whole stated range lies above it.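

Adding the methyl on this aromatic carbon, ortho to a large group, gives in this assay a 3.4-fold lower number from compound 2 to compound 3 (0.53 log units; beyond the scatter), so here the added methyl goes with higher toxicity in this test. The other new step also adds a methyl, this time to compound 1, and gives an at least 9.8-fold lower number from compound 1 to compound 3 (0.99 log units; beyond the scatter), so both steps into the compound with two methyls lower the number. The size of this second step is only a minimum, because the reading for compound 1 is a limit and not a number: the limit of > 387000 nM in this assay, at which 1 of the 3 values shown sits.

Still open, on these data alone, is whether the drop belongs to a methyl specifically or would also follow a longer chain, such as ethyl, at this carbon. An amine or a carboxylic acid in the same place could move the number differently.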